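The source may report more compounds than this note shows. Statements on the series, on what has been measured and on what is new or still open speak of the compounds shown alone.

In a functional assay on L02 cells (Homo sapiens) for inhibition, read by Griess assay, with stated times of 1 h and 24 h (a higher number here means a weaker inhibitor, a lower number a stronger inhibitor), compound 1 `COc1cc(/C=C/c2nc(N(C)C)c3sccc3n2)cc(OC)c1OC` gives > 1000000 nM, which is a limit of the assay and not a number. Among the compounds with values here, compound 2 `COc1ccc(Nc2nc(/C=C/c3cc(OC)c(OC)c(OC)c3)nc3ccsc23)cc1` gives 279000 nM, the only actual number so far. Compound 3 `COc1cc(/C=C/c2nc(NCc3ccc(Cl)cc3)c3sccc3n2)cc(OC)c1OC` has 4-chlorobenzyl in place of 4-methoxyphenyl on a nitrogen on an aromatic ring. Within the data shown here, the only measured step, an at least 3.5-fold lower number from compound 1 to compound 2 (0.55 log units; beyond the scatter), replaced dimethylamino with (4-methoxyphenyl)amino at the same spot, so it is a loose guide. Compound 3 keeps a six-membered aromatic ring of carbon only, so no change beyond the scatter is expected in this assay. The expected step is a 1.3-fold lower number from compound 2 to compound 3 (0.10 log units; within the scatter). For compound 3 the estimated value is 220000 nM, within an expected range of 70000 nM to 700000 nM.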

Compound 3, half-maximal inhibitory concentration: > 1000000 nM
Compound 3: a limit, no number (the forecaster's own chance of this, stated with the estimate: 20%); middle value at least 4.5-fold (0.65 log units) from the limit.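

In this assay, replacing 4-methoxyphenyl with 4-chlorobenzyl on this nitrogen is not a neutral change, giving an at least 3.5-fold higher number from compound 2 to compound 3 (0.55 log units; beyond the scatter). A six-membered aromatic ring of carbon only in the group on the nitrogen is therefore not enough to keep the value of compound 2. Compound 3 gives only a limit, so the full size of that step is unknown, and the step between compound 1 and compound 3 cannot be read: the limit of > 1000000 nM in this assay, at which 2 of the 3 values shown sit.

The compounds shown leave open whether the chlorine or the extra carbon of the benzyl group carries the step. A 4-chlorophenyl or 4-methoxybenzyl group on the same nitrogen would separate the two.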